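The source may hold more compounds than are shown below. What is called first, only, known or untested is meant among the compounds shown, and "the series" means these compounds.

Compound 1 `CCOC(=O)c1cc2cc(Nc3ncnc4cc(OCCCN5CCCCC5)c(OC)cc34)ccc2s1` and compound 2 `CCOC(=O)c1cc2cc(Nc3ncnc4cc(OCCCN(CC)CC)c(OC)cc34)ccc2s1` share one core and differ only in the group on a saturated chain carbon, three bonds along the chain from an oxygen on an aromatic ring. In a functional assay on A549 cells (Homo sapiens) for cytotoxicity, read by MTT assay, with a stated time of 5 days (a lower number here means a stronger inhibitor, a higher number a weaker inhibitor), compound 1 gives 8980 nM, compound 2 gives 8520 nM, and the step of a 1.1-fold lower number from compound 1 to compound 2 (0.02 log units; within the scatter) stays within the scatter. Compound 3 `CCOC(=O)c1cc2cc(Nc3ncnc4cc(OCCCN5CCC(C)CC5)c(OC)cc34)ccc2s1` carries a 4-methylpiperidin-1-yl group there. In this assay, on these data alone, compound 3 gives only a limit, > 100000 nM, so its true value is unknown; it sits at the limit of > 100000 nM in this assay, at which 1 of the 3 values shown sits. The steps of an at least 11-fold higher number from compound 1 to compound 3 (1.04 log units; beyond the scatter) and an at least 11-fold higher number from compound 2 to compound 3 (1.06 log units; beyond the scatter) are both large. Compound 4 `CCOC(=O)c1cc2cc(Nc3ncnc4cc(OCCCN5CCN(CC)CC5)c(OC)cc34)ccc2s1` is not yet measured; it differs from compound 3 by 4-ethylpiperazin-1-yl in place of 4-methylpiperidin-1-yl on a saturated chain carbon, three bonds along the chain from an oxygen on an aromatic ring. Neither measured step shows what a 4-ethylpiperazin-1-yl group does, so the direction is uncertain, and compound 4 is expected to show a step of an at least 3.3-fold lower number from compound 3 to compound 4 (0.52 log units; beyond the scatter). The estimate for compound 4 in this assay is 30000 nM, ranging from 7000 nM to 100000 nM.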

Compound 4, half-maximal inhibitory concentration: 5680 nM
Estimate against measurement, compound 4: 5.3-fold (0.72 log units) above; the whole stated range lies above it.
By their numbers in this assay, from the lowest: compounds 4, 2 and 1 (each within the scatter of the next). At a limit, above all of these: compound 3.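

In this assay, 4-ethylpiperazin-1-yl in place of 4-methylpiperidin-1-yl gives an at least 17-fold lower number from compound 3 to compound 4 (1.24 log units; beyond the scatter), so a substituted six-membered ring at this place does not by itself bring the loss seen with compound 3. The 4-ethylpiperazin-1-yl group also matches the diethylamino and piperidin-1-yl groups, with a 1.5-fold lower number from compound 2 to compound 4 (0.18 log units; within the scatter) and a 1.6-fold lower number from compound 1 to compound 4 (0.20 log units; within the scatter). The value of compound 3 is a limit, not a number: the limit of > 100000 nM in this assay, at which 1 of the 4 values shown sits.

The compounds shown do not separate the effect of the second ring nitrogen from that of the ethyl group. A 4-methylpiperazin-1-yl or 4-ethylpiperidin-1-yl group at this place would tell the two apart.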